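The source may hold more compounds than are shown below. What is called first, only, known or untested is meant among the compounds shown, and "the series" means these compounds.

Measured in a functional assay on HeLa cells (Homo sapiens) for inhibition, read by MTT assay, with a stated time of 48 h; on this read-out higher numbers stand for weaker inhibition and lower numbers for stronger inhibition:
- compound 1 `CCOC(=O)C1=C(NN=C(C(C)=O)C(C)=O)Nc2[nH]nc(C)c2C1c1ccc(N(C)C)cc1`: 17000 nM
- compound 2 `CCOC(=O)C1=C(N/N=C(\C#N)C(N)=O)Nc2[nH]nc(C)c2C1c1ccc(N(C)C)cc1`: 47300 nM
- compound 3 `CCOC(=O)C1=C(N/N=C(/C(=O)Br)c2ccc(Br)cc2)Nc2[nH]nc(C)c2C1c1ccc(N(C)C)cc1`: 68500 nM

Compound 3 stands at the upper, weaker end of these numbers, together with compound 2, and the gap between the two is small: a 1.4-fold higher number from compound 2 to compound 3 (0.16 log units; within the scatter). Both lie clear of compound 1, as shown by a 2.8-fold higher number from compound 1 to compound 2 (0.44 log units; beyond the scatter) and by a 4.0-fold higher number from compound 1 to compound 3 (0.61 log units; beyond the scatter).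

The next compound, compound 4 `CCOC(=O)C1=C(N/N=C(/Cl)c2ccc([N+](=O)[O-])cc2)Nc2[nH]nc(C)c2C1c1ccc(N(C)C)cc1`, keeps the shared core and alters only the group on the amine nitrogen: a group of 12 heavy atoms (7 carbon, 2 nitrogen, 2 oxygen, 1 chlorine; one six-membered aromatic ring of carbon only) in place of a group of 12 heavy atoms (8 carbon, 1 nitrogen, 1 oxygen, 2 bromine; one six-membered aromatic ring of carbon only), on an amine nitrogen. A six-membered aromatic ring of carbon only remains in the group that enters.

All three measured steps change this same group, and the largest of them is still modest: a 4.0-fold higher number from compound 1 to compound 3 (0.61 log units; beyond the scatter). Within the data shown here, none of them swaps one ring-bearing group for another, so the data offer no direct precedent for this exchange. The closest guide is therefore compound 3 itself, at 68500 nM, with compound 2 close by in the same range.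

In this assay, no step beyond the scatter is therefore expected, with at most a slight drift toward the lower number. The estimated step is a 1.5-fold lower number from compound 3 to compound 4 (0.18 log units; within the scatter). For compound 4 the expected value is 45000 nM, with an estimated range of 17000 nM to 115000 nM.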

Compound 4, half-maximal inhibitory concentration: 46200 nM
For compound 4 the middle estimate is 1.0-fold (0.01 log units) below the measured one, within the range that was stated.
By their numbers in this assay, from the lowest: compound 1; then compounds 4, 2 and 3 (each within the scatter of the next).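

Among these compounds, this is the first exchange at the amine nitrogen of one group bearing a six-membered aromatic ring for another, and in this assay it stays within the scatter, with a 1.5-fold lower number from compound 3 to compound 4 (0.17 log units; within the scatter). The presence of that ring does not by itself set the values apart, since the step to the ring-bearing group from the ringless group of compound 2 is also within the scatter, with a 1.0-fold lower number from compound 2 to compound 4 (0.01 log units; within the scatter). Compound 1 stays apart from the ring-bearing compound 4 as well, with a 2.7-fold higher number from compound 1 to compound 4 (0.43 log units; beyond the scatter), a step beyond the scatter, but compound 2 goes against any reading that a ringless group gives the lower number, and no supporting measurement is available to explain this difference.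

The exchange from compound 3 to compound 4 alters the halogen and the substituent on the aromatic ring together, so the shown compounds cannot separate their contributions. On these data alone, it also remains open whether an unsubstituted phenyl ring, a ring carrying an amine or a carboxylic acid, or a longer chain in this place would stay in the same range or come closer to compound 1.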